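The source may report more compounds than this note shows. Statements on the series, on what has been measured and on what is new or still open speak of the compounds shown alone.

Compound 1, `O=C(NCc1ccccc1)c1csc(-c2c[nH]c3ccccc23)n1`, gives > 100000 nM in a functional assay on LNCaP cells (Homo sapiens) for cytotoxicity, read by MTT assay, with a stated time of 48 h, in the presence of a further agent that is not named here; a lower number here means a stronger inhibitor, a higher number a weaker inhibitor; this is a limit of the assay, not a number.
Compound 2, `COc1ccc(NC(=O)c2csc(-c3cn(Cc4ccc(Cl)cc4)c4ccccc34)n2)cc1`, gives > 100000 nM in this assay; again only a limit.
Compound 3, `COc1cc(NC(=O)c2csc(-c3c[nH]c4ccc(Br)cc34)n2)cc(OC)c1OC`, gives > 100000 nM in this assay; again only a limit.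

Compound 1 thus stands at the limit of > 100000 nM in this assay, at which 3 of the 3 values shown sit, so nothing places it against the other two beyond that limit. Compound 4, `Cc1ccc(NC(=O)c2csc(-c3c[nH]c4ccccc34)n2)cc1`, differs from it by 4-methylphenyl in place of benzyl on an amide-type nitrogen. Because compound 1 sits at the limit of > 100000 nM in this assay, at which 3 of the 3 values shown sit, and compounds 2 and 3 with other groups on that amide nitrogen sit at the same limit, no step beyond the scatter is expected here, in either direction. The expected step reads a number no higher from compound 1 to compound 4 (the limit leaves the size open). Compound 4 is accordingly estimated at 100000 nM, with a range from 30000 nM to 300000 nM, most likely reported again only as a limit.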

Compound 4, half-maximal inhibitory concentration: > 100000 nM
Compound 4: no number, only a limit; the forecaster's own chance of this, stated with the estimate: 85%; the middle value sits exactly at the limit.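

Compound 4 gives > 100000 nM in this assay, again only a limit, and compound 1 also has only a limit, so no step can be read between compound 1 and compound 4. The compounds shown leave open whether any group on the amide nitrogen would give a measurable number in this assay.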